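This account rests on a few compounds, and the source may have more. Where it says the series, first, only, none or still open, it means among the compounds named here.

Measured in a functional assay on HepG2 cells (Homo sapiens) for inhibition, read by MTT assay, with a stated time of 72 h; on this read-out lower numbers stand for stronger inhibition and higher numbers for weaker inhibition:
- Compound 1 `Nc1nc2cc(-c3nn(CCCC(=O)NO)c4ncnc(N)c34)ccc2o1` gives > 50000 nM (a limit of the assay, not a number)
- Compound 2 `Nc1ncnc2c1c(-c1cnc3[nH]ccc3c1)nn2CCCCC(=O)NO` gives 36700 nM

Of these two compounds, only compound 2 has an actual number in this assay, and that number is 36700 nM. Compound 1 stands at > 50000 nM, which is a limit of the assay.

The next compound, compound 3 `Nc1ncnc2c1c(-c1cnc3[nH]ccc3c1)nn2CCCC(=O)NO`, has not yet been measured. It differs from compound 2 in one place, where the 4-(hydroxycarbamoyl)butyl chain gives way to 3-(hydroxycarbamoyl)propyl: hydroxycarbamoyl in place of (hydroxycarbamoyl)methyl on a saturated chain carbon, three bonds along the chain from an aromatic nitrogen. Among the compounds with values here, no measured pair in this small set shows what such a change does, so the expectation rests mainly on compound 2 at 36700 nM. The expected change is a 1.1-fold higher number from compound 2 to compound 3 (0.04 log units; within the scatter), which is estimated to lie within the scatter, with only a slight lean toward weaker inhibition. A result reported only as a limit would not be a surprise. For compound 3 the estimated value is 40000 nM, with an expected range from 18000 nM to 80000 nM.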

Compound 3, half-maximal inhibitory concentration: > 50000 nM
Compound 3 ended at the assay's limit; the forecaster's own chance of this, stated with the estimate: 40%; middle value at least 1.2-fold (0.09 log units) from the limit.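

In this assay, within the data shown here, shortening 4-(hydroxycarbamoyl)butyl to 3-(hydroxycarbamoyl)propyl, on a saturated chain carbon three bonds along the chain from an aromatic nitrogen, gives an at least 1.3-fold higher number from compound 2 to compound 3 (0.13 log units; that floor lies within the scatter), the first reading of any change at this position. Among these compounds, that step is only a floor, and since the floor lies within the scatter, the result does not establish that the shorter chain weakens inhibition; it shows only that this change brings no lower number. How large the step really is cannot be told because the reading for compound 3 is a limit of the assay and not a number, and the set as a whole runs up against that same limit: the limit of > 50000 nM in this assay, at which 2 of the 3 values shown sit.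

From the compounds shown here alone, compound 1 and compound 3 share the 3-(hydroxycarbamoyl)propyl chain and both give only a limit, so what the other part of these molecules contributes on that chain stays open. Also open, going by these compounds, is whether a longer chain, such as 5-(hydroxycarbamoyl)pentyl, or a carboxylic acid in place of the hydroxycarbamoyl group would bring the number down from that of compound 2.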